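Growing the Small Ring on a Shared Core

A few compounds are considered here, and "the series" means these few. Any claim that something is new, unique, unknown or untested is made for them only; others in the source may bear on it.

Compound 2 `O=c1cc(C2CCC2)oc2ccc(OCCCCCCN3CCCCC3)cc12`: 34 nM
Compound 1 `O=c1cc(-c2ccccc2)oc2ccc(OCCCCCCN3CCCCC3)cc12`: 54 nM

Both numbers come from an assay on isolated protein (Cavia porcellus) with Sigma non-opioid intracellular receptor 1 (Homo sapiens) as the target, read by radioligand binding; on this read-out lower numbers stand for stronger inhibition and higher numbers for weaker inhibition. Compound 2 shows the lower of the two, but the step of a 1.6-fold lower number from compound 1 to compound 2 (0.20 log units; within the scatter) means the pair cannot be told apart. Compound 3 `O=c1cc(C2CCCC2)oc2ccc(OCCCCCCN3CCCCC3)cc12` has not yet been measured; it differs from compound 2 by cyclopentyl in place of cyclobutyl on an aromatic carbon. Within the data shown here, the only measured step that bears on this, replacing phenyl with cyclobutyl, barely moved the number, and cyclobutyl to cyclopentyl is a smaller change still. For compound 3 the expected step of a 1.1-fold lower number from compound 2 to compound 3 (0.05 log units; within the scatter) is therefore none beyond the scatter, and its estimated value in this assay is 30 nM, ranging from 12 nM to 75 nM.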

Compound 3, half-maximal inhibitory concentration: 38 nM
Compound 3: the middle estimate sits 1.3-fold (0.10 log units) below what was measured; the measured number falls inside the stated range.
By their numbers in this assay, from the lowest: compounds 2, 3 and 1 (each within the scatter of the next).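

In this assay, enlarging the small ring by one carbon gives a 1.1-fold higher number from compound 2 to compound 3 (0.05 log units; within the scatter) and replacing phenyl with cyclopentyl gives a 1.4-fold lower number from compound 1 to compound 3 (0.15 log units; within the scatter), so neither step can be told from the scatter. Among these three compounds, a four-membered ring, a five-membered ring and phenyl at this position therefore give numbers that cannot be separated. Nothing available explains why these groups give such similar numbers. Still open, on these data alone, is whether a larger cyclohexyl ring would keep the number in this range, and whether an amine or a carboxylic acid on the ring would shift it.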